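The compounds below may be only part of what the source reports. "The series", "measured", "known", "first", "only" and "open" are said of these compounds alone.

The measured compounds and their values:

compound 1, `COc1ccc(OC)c(-c2cc(=O)c3c(OC)c(OC)c(OC)c(OC)c3o2)c1`, 4 ug/mL
compound 2, `COc1cc(OC)c(-c2cc(=O)c3c(OC)c(OC)c(OC)c(OC)c3o2)cc1OC`, 13 ug/mL
compound 3, `COc1cc(OC)cc(-c2cc(=O)c3c(OC)c(OC)c(OC)c(OC)c3o2)c1`, 3 ug/mL

All three were tested in a functional assay on KB cells (Homo sapiens) for cytotoxicity; a lower number here means that less compound is needed, a higher number that more compound is needed for the effect. Compound 1 and compound 2 share a core and differ by methoxy in place of hydrogen on an aromatic carbon; this change gave a 3.3-fold higher number from compound 1 to compound 2 (0.51 log units; beyond the scatter). Compound 3 has the same atoms as compound 1 joined differently; the difference between the two cores is not broken down here. In this assay compound 3 lies within the scatter of compound 1 and beyond the scatter of compound 2, so compound 3 and compound 1 cannot be put in order against each other.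

Compound 4, `COc1cc(-c2cc(=O)c3c(OC)c(OC)c(OC)c(OC)c3o2)cc(OC)c1OC`, has not yet been measured in this assay. It is derived from compound 3 by methoxy in place of hydrogen on an aromatic carbon. Going by the values given here, this is the same kind of change as the one from compound 1 to compound 2, but not the same: in compound 2 the entering group sits ortho to a methoxy group and meta to a methoxy group, whereas in compound 4 it sits ortho to two methoxy groups, para to a large group in both cases.

Among the compounds with values here, with only one earlier example of this kind of change, the expectation for compound 4 rests on a 3.3-fold higher number from compound 1 to compound 2 (0.51 log units; beyond the scatter), and a step of similar size, a 3.0-fold higher number from compound 3 to compound 4 (0.48 log units; beyond the scatter), is expected. Compound 4 is therefore estimated at 9 ug/mL, most likely between 4 ug/mL and 25 ug/mL.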

Compound 4, concentration for half-maximal effect: 0.5 ug/mL
Estimate against measurement, compound 4: 18-fold (1.26 log units) above, outside the stated range (below it).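

In this assay, methoxy in place of hydrogen on an aromatic carbon gave a 6.0-fold lower number from compound 3 to compound 4 (0.78 log units; beyond the scatter). Set beside the earlier case, the same change moved the number in opposite directions on the two cores, so in this series its outcome on one core cannot be carried over to the other: the same change on two cores in this assay, a 3.3-fold higher number (0.51 log units; beyond the scatter) from compound 1 to compound 2 and a 6.0-fold lower number (0.78 log units; beyond the scatter) from compound 3 to compound 4, 20-fold (1.29 log units) apart, beyond the scatter of two such steps What this does not show is the source of the difference: there are only two such pairs, and although the entering methoxy in compound 4 sits ortho to two methoxy groups, para to a large group, the data cannot separate that placement from the other differences between the cores, nor do they give a rule for any further core.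

Every substituent on the compounds shown is a methoxy group, so it remains open whether a hydroxy group or a longer chain such as ethoxy, at the place where compound 4 carries its added methoxy, would keep a number near that of compound 4, which is 0.5 ug/mL as measured. As far as these compounds go, it also remains open whether an amine or a fluorine atom at that place would follow either of the two steps.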